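The source may hold more compounds than are shown below. What is called first, only, known or untested is meant among the compounds shown, and "the series" means these compounds.

Compounds measured so far:
compound 1, `Cc1cc2c(cc1C(=O)N=C(N)N)S(=O)(=O)CC2C(C)C`, 21 nM
compound 2, `Cc1cc2c(cc1C(=O)N=C(N)N)S(=O)(=O)CC2N`, 116 nM
compound 3, `Cc1cc2c(cc1C(=O)N=C(N)N)S(=O)(=O)CC2O`, 70 nM

All three share one core and differ only in the group on a saturated ring carbon. In an assay on cells for inhibition of sodium/hydrogen exchanger (Oryctolagus cuniculus) (a higher number here means a weaker inhibitor, a lower number a stronger inhibitor), compound 1, with isopropyl there, gives 21 nM, the lowest of the three numbers. Compound 3, with hydroxy, stands second highest: it sits a 3.3-fold higher number from compound 1 to compound 3 (0.52 log units; beyond the scatter), while the comparison with compound 2 shows a 1.7-fold lower number from compound 2 to compound 3 (0.22 log units; within the scatter), so compound 2 and compound 3 cannot be told apart.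

Compound 4, `COC1CS(=O)(=O)c2cc(C(=O)N=C(N)N)c(C)cc21`, carries the change (methyl in place of hydrogen on an oxygen on a saturated carbon). Within the data shown here, no measured step swaps exactly this pair of groups. Among the measured compounds shown here, the steps that bear on it are those at the same ring carbon: a 3.3-fold higher number from compound 1 to compound 3 (0.52 log units; beyond the scatter) and a 5.5-fold higher number from compound 1 to compound 2 (0.74 log units; beyond the scatter), both modest. Since one small group replaces another at the same spot, the step is expected to be small, and within or only just beyond the scatter. The expected step is a 1.6-fold lower number from compound 3 to compound 4 (0.19 log units; within the scatter). Compound 4 is therefore estimated at 45 nM, with a range from 15 nM to 130 nM.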

Compound 4, half-maximal inhibitory concentration: 96 nM
Compound 4: the middle estimate sits 2.1-fold (0.33 log units) below what was measured; the range from low to high includes it.
By their numbers in this assay, from the lowest: compound 1; then compounds 3, 4 and 2 (each within the scatter of the next).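

In this assay, swapping the hydroxy hydrogen for methyl produces no readable change: the step is a 1.4-fold higher number from compound 3 to compound 4 (0.14 log units; within the scatter), so this hydrogen can be capped without a difference that this assay can detect. Methoxy also cannot be told apart from amino, with a 1.2-fold lower number from compound 2 to compound 4 (0.08 log units; within the scatter), whereas isopropyl remains clearly separate, with a 4.6-fold higher number from compound 1 to compound 4 (0.66 log units; beyond the scatter), so among these four compounds, hydroxy, amino and methoxy sit at one level and isopropyl alone gives a lower number. Nothing available explains this difference between isopropyl and the other three groups.

Isopropyl is the only group here attached through carbon, so it remains open whether a methyl or an ethyl at this ring carbon would match isopropyl or the other three groups. As far as these compounds go, whether a longer ether chain, such as propoxy, would stay level with methoxy is also open.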